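Chlorophenyl Swap Tested Against a Shared Assay Limit

This account rests on a few compounds, and the source may have more. Where it says the series, first, only, none or still open, it means among the compounds named here.

Measured compounds in a functional assay on HepG2 cells (Homo sapiens) for antiproliferative activity, read by MTT assay, with a stated time of 48 h (a lower number here means a stronger inhibitor, a higher number a weaker inhibitor), each value being a limit of the assay rather than a number:
compound 1 `N#CC1=C(N)Oc2c(c3nc4ccccc4nc3c3ccccc23)C12C(=O)N(Cc1cnnn1-c1ccc(Cl)cc1)c1ccccc12` gives > 50000 nM.
compound 2 `N#CC1=C(N)Oc2c(c3nc4ccccc4nc3c3ccccc23)C12C(=O)N(Cc1cnnn1-c1ccccc1Cl)c1ccccc12` gives > 50000 nM.
compound 3 `N#CC1=C(N)Oc2c(N)cc3nc4ccccc4nc3c2C12C(=O)N(Cc1cnnn1-c1ccc(Cl)cc1)c1ccccc12` gives > 50000 nM.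

All three measured compounds sit at the same limit, so none of them can be placed above or below another. Compound 1 and compound 2 differ by 2-chlorophenyl in place of 4-chlorophenyl on an aromatic nitrogen. The step that the two limits leave unreadable from compound 1 to compound 2 cannot be read in size because of the limit of > 50000 nM in this assay, at which 3 of the 3 values shown sit. Compound 3 carries a different core from compound 1; the difference between the two cores is not broken down here. Going by the values given here, compound 4 `N#CC1=C(N)Oc2c(N)cc3nc4ccccc4nc3c2C12C(=O)N(Cc1cnnn1-c1ccccc1Cl)c1ccccc12` is not yet measured and differs from compound 3 by 2-chlorophenyl in place of 4-chlorophenyl on an aromatic nitrogen, the same change as the one from compound 1 to compound 2.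

The expectation for compound 4 rests only on the fact that compound 3 gives > 50000 nM and that the earlier swap produced a step that two limits leave unreadable. Compound 4 is therefore expected to show a step that the limit leaves unreadable from compound 3 to compound 4, which is to say that nothing measurable is expected to change. Compound 4 is estimated at 60000 nM, with a range from 20000 nM to 200000 nM, and most likely the assay will again report only a limit.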

Compound 4, half-maximal inhibitory concentration: 33500 nM
For compound 4 the middle estimate is 1.8-fold (0.25 log units) above the measured one; the measured number falls inside the stated range.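

In this assay, going by these compounds alone, placing 2-chlorophenyl where 4-chlorophenyl stood on the core of compound 3 gives an at least 1.4-fold lower number from compound 3 to compound 4 (0.17 log units; that floor lies within the scatter), and compound 4 is the only one of the four compounds to return a number rather than a limit. Compound 3 gives > 50000 nM, which is a limit of the assay, so the step has a floor but no known size, and that floor does not establish a change beyond ordinary repeat variation. The result therefore shows a readable outcome for the swap on one core only and does not show that the change carries from one core to the other, because the matching step on the core of compound 1 cannot be read, as both of its ends sit at a limit: the limit of > 50000 nM in this assay, at which 3 of the 4 values shown sit.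

The compounds shown leave open how a plain phenyl or a benzyl group would read in this assay when attached in place of the chlorophenyl on the 1H-1,2,3-triazol-5-yl unit. They also leave open whether 2-chlorophenyl would give a readable number on any core beyond that of compound 3.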